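The source may hold more compounds than are shown below. What is called first, only, known or untested is meant among the compounds shown, and "the series" means these compounds.

Measured compounds:
Compound 1 `Cc1nc(CN2CCN(c3cccc4[nH]c(-c5ccc(C(C)(C)C)cc5)nc34)CC2)c[nH]1` gives, in a functional assay on HEK293 cells for antagonist activity at Gonadotropin-releasing hormone receptor (Homo sapiens) (on this read-out lower numbers stand for stronger inhibition and higher numbers for weaker inhibition), 44 nM.
Compound 2 `CCCCn1cnc(CN2CCN(c3cccc4[nH]c(-c5ccc(C(C)(C)C)cc5)nc34)CC2)c1C` gives, in this assay, 71 nM.

Compound 2 stands together with compound 1 within the scatter; the two numbers cannot be ordered. Among the measured compounds shown here, the single step on record, a 1.6-fold higher number from compound 1 to compound 2 (0.21 log units; within the scatter), changed the same substituent and stayed within the scatter. Compound 3 `Cc1nc(CN2CCN(c3cccc4[nH]c(-c5ccc(C(C)(C)C)cc5)nc34)CC2)cn1C` differs from compound 2 in that (1,2-dimethyl-1H-imidazol-4-yl in place of 1-butyl-5-methyl-1H-imidazol-4-yl on a saturated chain carbon bound to an amine nitrogen in a ring). Because the step of a 1.6-fold higher number from compound 1 to compound 2 (0.21 log units; within the scatter) bore on this position and was small, no step beyond the scatter is expected in this assay, that is a 1.3-fold lower number from compound 2 to compound 3 (0.11 log units; within the scatter). Compound 3 is therefore estimated at 55 nM, with a range of 20 nM to 150 nM.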

Compound 3, half-maximal inhibitory concentration: 23 nM
Compound 3: the middle estimate sits 2.4-fold (0.38 log units) above what was measured, and the stated range covers the measured number.
By their numbers in this assay, from the lowest: compounds 3, 1 and 2 (each within the scatter of the next, the first and the last beyond it).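

This position does respond to the substituent in this assay: 1,2-dimethyl-1H-imidazol-4-yl in place of 1-butyl-5-methyl-1H-imidazol-4-yl gives a 3.1-fold lower number from compound 2 to compound 3 (0.49 log units; beyond the scatter), a step beyond the scatter. By contrast, methyl in place of hydrogen on the aromatic nitrogen gives a 1.9-fold lower number from compound 1 to compound 3 (0.28 log units; within the scatter), which stays within the scatter. Nothing available explains either step.

Compound 2 and compound 3 differ in more than one feature of the ring, so the butyl group and the placement of the ring methyl cannot be separated. From the compounds shown here alone, how an ethyl or a 2-methoxyethyl group on the aromatic nitrogen would read remains open.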